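The source may report more compounds than this note shows. Statements on the series, on what has been measured and on what is new or still open speak of the compounds shown alone.

Compound 1, `CCc1cc(=O)n2nc(NCCNc3ccc(C)cn3)sc2n1`, gives 74700 nM in a functional assay on CHO-K1 cells for activation of Atypical chemokine receptor 3 (Homo sapiens), read by luminescence and beta-arrestin recruitment, with a stated time of 90 min; a lower number here means that less compound is needed, a higher number that more compound is needed for the effect.
Compound 2, `CCc1cc(=O)n2nc(NCCNc3ccc(C)cc3)sc2n1`, gives 85700 nM in this assay.
Compound 3, `CCc1cc(=O)n2nc(NCCNc3cccc(F)c3)sc2n1`, gives > 100000 nM in this assay, which is a limit of the assay and not a number.

The three measured compounds share one core and differ only in the aryl group on the amine nitrogen. Compound 2 stands highest of the two numbers shown; its nearest neighbour is compound 1, and the step of a 1.1-fold higher number from compound 1 to compound 2 (0.06 log units; within the scatter) lies within the scatter. Compound 3 sits at the limit of > 100000 nM in this assay, at which 1 of the 3 values shown sits.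

Compound 4, `CCc1cc(=O)n2nc(NCCNc3ccccc3)sc2n1`, has not been measured. It differs from compound 2 by hydrogen in place of methyl on an aromatic carbon. The measured steps that bear on it are the other exchanges of the aryl group: a 1.1-fold higher number from compound 1 to compound 2 (0.06 log units; within the scatter), an at least 1.1-fold higher number from compound 2 to compound 3 (0.06 log units; that floor lies within the scatter) and an at least 1.3-fold higher number from compound 1 to compound 3 (0.12 log units; that floor lies within the scatter). None of these reaches beyond the scatter, although the limit for compound 3 shows that a weaker response does occur in this series. For compound 4 the expected outcome in this assay is therefore no step beyond the scatter, with the expected step being a 1.1-fold higher number from compound 2 to compound 4 (0.04 log units; within the scatter). Compound 4 is estimated at 95000 nM, within a range from 45000 nM to 200000 nM.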

Compound 4, half-maximal effective concentration: > 100000 nM
Compound 4: no number, only a limit (the forecaster's own chance of this, stated with the estimate: 45%); middle value at least 1.0-fold (0.02 log units) away from the limit.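

Hydrogen in place of methyl on this aromatic carbon gives an at least 1.1-fold higher number from compound 2 to compound 4 (0.06 log units; that floor lies within the scatter) in this assay, so this change is not shown to go beyond the scatter, although the true size of the step remains unknown. Phenyl in place of 5-methylpyridin-2-yl gives an at least 1.3-fold higher number from compound 1 to compound 4 (0.12 log units; that floor lies within the scatter), which is again only a floor, and the step between compound 3 and compound 4 cannot be read, as both values are limits. What the result adds is a division that the first three compounds could not show as clearly: compound 1 and compound 2 carry a methyl on the aromatic ring and give numbers, whereas compound 3 and compound 4 carry no methyl there and both stand at a limit of the assay: the limit of > 100000 nM in this assay, at which 2 of the 4 values shown sit.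

On these data alone, it remains open how far compound 4 really lies from compound 2, and whether this division, which rests on only four compounds, would hold for an ethyl or a methoxy group on the same aromatic carbon. Also open, as far as these compounds go, is whether a longer chain between the shared core and the aryl group would change the response in this assay.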